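A few compounds are considered here, and "the series" means these few. Any claim that something is new, unique, unknown or untested is made for them only; others in the source may bear on it.

The shared core appears in compound 1 `Oc1cccc(-c2cc(-c3ccsc3)cc(-c3ccccc3O)n2)c1`, which in a functional assay on T47D cells (Homo sapiens) for cytotoxicity, read by CCK-8 assay (a lower number here means a stronger inhibitor, a higher number a weaker inhibitor), gives > 50000 nM, a limit of the assay. Compound 2 `Oc1cccc(-c2cc(-c3ccco3)cc(-c3ccccc3O)n2)c1` gives 820 nM in this assay. Compound 3 `Oc1ccccc1-c1cc(-c2ccoc2)cc(-c2ccccc2O)n1` in this assay gives > 50000 nM, again a limit, and so stands at the limit of > 50000 nM in this assay, at which 2 of the 3 values shown sit. Compound 4 `Oc1cccc(-c2cc(-c3ccoc3)cc(-c3ccccc3O)n2)c1` differs from compound 3 by 3-hydroxyphenyl in place of 2-hydroxyphenyl on an aromatic carbon. Within the data shown here, no measured pair differs in the hydroxyphenyl group alone; the only measured step, an at least 60-fold lower number from compound 1 to compound 2 (1.78 log units; beyond the scatter), alters the five-membered ring and so does not bear on this change. Starting from a limit for compound 3, the step cannot be sized from the data. Compound 4 is expected at about 15000 nM in this assay, plausibly between 1500 nM and 50000 nM. That estimate amounts to an expected step of an at least 3.3-fold lower number from compound 3 to compound 4 (0.52 log units; beyond the scatter).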

Compound 4, half-maximal inhibitory concentration: > 50000 nM
Compound 4: only a limit was reported (the forecaster's own chance of this, stated with the estimate: 45%); middle value at least 3.3-fold (0.52 log units) away from the limit.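

Exchanging furan-2-yl for furan-3-yl gives an at least 60-fold higher number from compound 2 to compound 4 (1.78 log units; beyond the scatter) and this shows that, at this place on the shared core, the attachment point of the furan alone can decide the result in this assay. Compound 2 is the only one of the four not reported as a limit of the assay: the limit of > 50000 nM in this assay, at which 3 of the 4 values shown sit. The steps to compound 4 from compound 1 and compound 3 cannot be read, as both ends are limits. Still open, going by these compounds, are whether exchanging the hydroxyphenyl groups matters when furan-2-yl is present, and whether an amine or a carboxylic acid tolerated in place of the furan would give a measurable value.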